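Nitrooxy in place of bromo: paw edema notes

A few compounds are considered here, and "the series" means these few. Any claim that something is new, unique, unknown or untested is made for them only; others in the source may bear on it.

Compound 1 `COc1ccc(C2=NN(C(=O)CBr)C(c3c(Cl)cccc3Cl)C2)cc1OC` and compound 2 `COc1ccc(C2=NN(C(=O)CO[N+](=O)[O-])C(c3c(Cl)cccc3Cl)C2)cc1OC` share one core; compound 3 `COc1ccc(C2=NN(C(=O)C(C)Br)C(c3ccco3)C2)cc1OC` and compound 4 `COc1ccc(C2=NN(C(=O)C(C)O[N+](=O)[O-])C(c3ccco3)C2)cc1OC` share another, and the difference between the two cores is not broken down here. In a functional assay on the whole organism (strain albino) for inhibition, with Rattus norvegicus as the target, read by paw edema, with stated times of 30 min and 3 h, at a dose of 100 mg/kg by the oral route (a higher number here means more inhibition at the dose given (going by the name of the read-out), a lower number less inhibition), compound 1 gives 69%, compound 2 gives 58% and compound 3 gives 42%. The change from compound 1 to compound 2 is nitrooxy in place of bromo on a saturated chain carbon bound to a carbonyl carbon and made a step of a number 11 percentage points lower from compound 1 to compound 2 (beyond the scatter). The change from compound 3 to compound 4 is nitrooxy in place of bromo on a saturated chain carbon bound to a carbonyl carbon and a saturated chain carbon; it is the same kind of change, though its place is a saturated chain carbon bound to a carbonyl carbon and a saturated chain carbon, whereas the earlier one sat on a saturated chain carbon bound to a carbonyl carbon. Because a number 11 percentage points lower from compound 1 to compound 2 (beyond the scatter) was a modest lowering, a step of similar size, a number 11 percentage points lower from compound 3 to compound 4 (beyond the scatter), is expected in this assay. Compound 4 is therefore estimated at 31%, with a range from 18% to 44%.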

Compound 4, a percentage reported as inhibition, in the whole organism at one dose (the size of the read-out at that dose, not a potency): 42%
Estimate against measurement, compound 4: 11 percentage points below, within the range that was stated.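

On the second core, in this assay, nitrooxy in place of bromo gives no change at the digits printed from compound 3 to compound 4 (within the scatter). Set beside the earlier step, the change reads alike on the two cores: the same change on two cores in this assay, a number 11 percentage points lower (beyond the scatter) from compound 1 to compound 2 and no change at the digits printed (within the scatter) from compound 3 to compound 4, 11 percentage points apart, within the scatter of two such steps. Among these compounds, this shows that the two steps cannot be told apart in this read-out, but it does not show that the change has the same size on every core, since there are only two pairs and the place on the chain also differs between them.

Open, going by these compounds, is how an amine or a carboxylic acid in place of bromo would read in this assay. Also open, on these data alone, is whether a longer chain carrying the nitrooxy group would give a step of similar size.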